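The source may hold more compounds than are shown below. What is called first, only, known or untested is meant among the compounds shown, and "the series" means these compounds.

Measured compounds in an assay on CHO cells for displacement of a labelled ligand from adenosine receptor A3 (Homo sapiens); a lower number here means a stronger inhibitor, a higher number a weaker inhibitor:
compound 1 `O=C(O)c1cnn(-c2nc(NC34CCC(CC3)C4)c3ncn([C@@H]4O[C@H](CO)[C@@H](O)[C@H]4O)c3n2)c1`: in this assay compound 1 gives only the limit > 5000 nM.
compound 2 `CCOC(=O)c1cnn(-c2nc(NC34CCC(CC3)C4)c3ncn([C@@H]4O[C@H](CO)[C@@H](O)[C@H]4O)c3n2)c1`: in this assay compound 2 gives 250 nM.

Compound 1 stands at the limit of this assay (the limit of > 5000 nM in this assay, at which 1 of the 2 values shown sits). Compound 3 `O=C(O)c1cnn(-c2nc(N[C@H]3CCCO3)c3ncn([C@@H]4O[C@H](CO)[C@@H](O)[C@H]4O)c3n2)c1` differs from compound 1 by a group of 5 heavy atoms (4 carbon, 1 oxygen; one five-membered non-aromatic ring with 1 hetero atom) in place of a group of 7 heavy atoms (7 carbon; 2 five-membered non-aromatic rings of carbon only), on a nitrogen on an aromatic ring. Among the compounds with values here, the single measured step, an at least 20-fold lower number from compound 1 to compound 2 (1.30 log units; beyond the scatter), alters the ester and leaves the amine untouched, so it does not bear on this change. With compound 1 sitting at the limit, a weak result is expected for compound 3 as well, the expected step being a step that the limit leaves unreadable from compound 1 to compound 3. Compound 3 is estimated at 8000 nM, range 2000 nM to 30000 nM.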

Compound 3, inhibition constant: 3210 nM
Beside the measured number, compound 3's estimate is 2.5-fold (0.40 log units) above it; the range from low to high includes it.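

In this assay, oxolan-2-yl in place of the all-carbon group of compound 1, on the nitrogen on the aromatic ring, gives an at least 1.5-fold lower number from compound 1 to compound 3 (0.19 log units; that floor lies within the scatter). Compound 3 therefore gives the first actual number for a carboxylic acid among these compounds, although no gain beyond the scatter can be claimed. The value for compound 1 is only a limit, so the true size of this step stays unread: the limit of > 5000 nM in this assay, at which 1 of the 3 values shown sits.

Still open, as far as these compounds go, is whether cyclopentyl on that nitrogen would match oxolan-2-yl, which would test the ring oxygen. Also open, from the compounds shown here alone, is whether an ethyl ester would lower the number with oxolan-2-yl in place, as in an at least 20-fold lower number from compound 1 to compound 2 (1.30 log units; beyond the scatter).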